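Removing a methyl from an acylthiourea inhibitor

The source may report more compounds than this note shows. Statements on the series, on what has been measured and on what is new or still open speak of the compounds shown alone.

Measured compounds:
Compound 1, `Cc1ccccc1NC(=S)NC(=O)c1ccccc1`: 3540 nM
Compound 2, `CC(=O)NC(=S)Nc1ccc(Br)c2ccccc12`: 2420 nM
Compound 3, `O=C(NC(=S)Nc1ccc(Br)c(C(F)(F)F)c1)c1ccccc1`: 1170 nM

In an assay for inhibition of epoxide hydrolase 1 (Homo sapiens), read by fluorescence, using microsomes (on this read-out higher numbers stand for weaker inhibition and lower numbers for stronger inhibition), compound 1 gives 3540 nM, the highest of the three numbers. Compound 2 gives 2420 nM, which lies within the scatter of compound 1, so no order between the two can be claimed. Compound 3 gives 1170 nM, a number that sits beyond the scatter below compound 1, and compound 3 is therefore the only one of the three that inhibits more strongly than compound 1 on this read-out.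

Compound 4, `O=C(NC(=S)Nc1ccccc1)c1ccccc1`, has not yet been measured in this assay. It differs from compound 1 in one place: hydrogen in place of methyl on an aromatic carbon, the carbon sitting ortho to a large group. For the measured compounds named here, no pair of measured compounds shows this change on its own, so its size has to be guessed. Going by the values given here, the shared core is kept intact and only one small group is lost; the step is expected to be modest and most likely to stay within the usual scatter, with no confident direction. Compound 4 is therefore estimated at 3000 nM, in the range 1200 nM to 8000 nM, which corresponds to an expected step of a 1.2-fold lower number from compound 1 to compound 4 (0.07 log units; within the scatter).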

Compound 4, half-maximal inhibitory concentration: 1290 nM
For compound 4 the middle estimate is 2.3-fold (0.37 log units) above the measured one; low and high end bracket the measured number.
By their numbers in this assay, from the lowest: compounds 3, 4, 2 and 1 (each within the scatter of the next, the first and the last beyond it).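

For the compounds shown here, replacing the methyl with hydrogen on the aromatic carbon ortho to a large group gives a 2.7-fold lower number from compound 1 to compound 4 (0.44 log units; beyond the scatter) in this assay, the first change in a single place that can be read in this set. The step lies beyond the usual scatter, so this methyl is not needed for inhibition on this read-out, and compound 4, which carries only hydrogen at this place, inhibits more strongly than compound 1. Nothing measured here explains why losing this one carbon strengthens inhibition.

Going by these compounds alone, whether a chlorine atom, a methoxy group or a longer chain such as ethyl on the same carbon would raise or lower the number remains open, since hydrogen and methyl are the only two groups compared at this place. As this is also the only step of its kind shown, it remains open whether the same change would have an effect of similar size on a different set of substituents elsewhere in the shared core.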